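The source may hold more compounds than are shown below. What is called first, only, known or untested is meant among the compounds shown, and "the series" means these compounds.

Compound 1 `O=c1[nH]cc(S(=O)(=O)Nc2cccc(-c3cn(-c4ccc(Cl)cc4)nn3)c2)c(=O)[nH]1`, compound 2 `O=c1[nH]cc(S(=O)(=O)Nc2ccc(-c3cn(-c4ccccc4)nn3)cc2)c(=O)[nH]1` and compound 3 `O=c1[nH]cc(S(=O)(=O)Nc2ccc(-c3cn(-c4ccccc4F)nn3)cc2)c(=O)[nH]1` share one core and differ in the substituents on the outer benzene. In an ADME assay on L02 cells (Homo sapiens) for cytotoxicity, read by MTT assay, with a stated time of 24 h (on this read-out lower numbers stand for higher toxicity in this test and higher numbers for lower toxicity in this test), compound 1 gives 9860 nM. Compound 2 is recorded in this assay as "not toxic" (no number reported). For compound 3 this assay reports only a limit, > 100000 nM, so no single number is known, and compound 3 stands among the least toxic entries shown, at the limit described by the limit of > 100000 nM in this assay, at which 1 of the 3 values shown sits. Compound 4 `O=c1[nH]cc(S(=O)(=O)Nc2ccc(-c3cn(-c4ccccc4Cl)nn3)cc2)c(=O)[nH]1` carries chloro in place of fluoro on an aromatic carbon. Among the measured compounds shown here, no measured pair shows this change, so a shift beyond the usual scatter is not expected in either direction. Compound 4 is therefore estimated at 100000 nM, with a range from 30000 nM to 300000 nM, a step of a number no higher from compound 3 to compound 4 (the limit leaves the size open).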

Compound 4, half-maximal cytotoxic concentration: 19300 nM
Compound 4: the middle estimate sits 5.2-fold (0.71 log units) above what was measured; measured number below the stated range.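

Among the compounds shown here, this is the first pair here that differs in one place, and in this assay the move from 2-fluorophenyl to 2-chlorophenyl gives an at least 5.1-fold lower number from compound 3 to compound 4 (0.71 log units; beyond the scatter), so this change, ortho to a large group, clearly raises toxicity in this test. The true step may be larger, since compound 3 is recorded only as a limit of the assay: the limit of > 100000 nM in this assay, at which 1 of the 4 values shown sits.

The compounds shown leave open how a methyl or methoxy group would read at this place. They also leave open whether the same exchange would give a similar step on other compounds.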